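A few compounds are considered here, and "the series" means these few. Any claim that something is new, unique, unknown or untested is made for them only; others in the source may bear on it.

In a functional assay on Caco-2 cells (Homo sapiens) for antiproliferative activity, read by MTT assay, with a stated time of 24 h (on this read-out lower numbers stand for stronger inhibition and higher numbers for weaker inhibition), compound 1, whose structure is `Clc1ccc(C2=NN(c3ccc(-c4ccccc4)nn3)C(c3ccccc3)C2)cc1`, gives 100000 nM. Compound 2, with the structure `Clc1ccc(C2=NN(c3ccc(-c4ccccc4)nn3)C(c3ccc(Cl)cc3)C2)cc1`, is reported only as a limit of this assay, namely > 100000 nM. Compound 3, with the structure `COc1ccc(C2CC(c3ccc(Cl)cc3)=NN2c2ccc(-c3ccccc3)nn2)cc1`, is likewise reported only as a limit of this assay, > 100000 nM. The step in this assay a number no lower from compound 1 to compound 2 (the limit leaves the size open) and the step of a number no lower from compound 1 to compound 3 (the limit leaves the size open) therefore cannot be sized. The change from compound 2 to compound 3 is methoxy in place of chloro on an aromatic carbon and the step that the two limits leave unreadable from compound 2 to compound 3 stays unreadable because the limit of > 100000 nM in this assay, at which 2 of the 3 values shown sit, hides its size.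

Compound 4, with the structure `COc1ccc(C2=NN(c3ccc(-c4ccccc4)nn3)C(c3ccccc3)C2)cc1`, has not yet been measured in this assay. Within the data shown here, it differs from compound 1 by methoxy in place of chloro on an aromatic carbon, the same change as the one made from compound 2 to compound 3, set at the same place on the same ring. The two starting cores, those of compound 1 and compound 2, differ by hydrogen in place of chloro on an aromatic carbon.

The step from compound 1 to compound 4 is expected to be no change at the digits printed from compound 1 to compound 4 (within the scatter), which rests on compound 1 sitting at 100000 nM and on the earlier step that the two limits leave unreadable from compound 2 to compound 3 giving no readable size for the same change. Compound 4 is estimated at 100000 nM in this assay. For compound 4 the expected range runs from 50000 nM to 200000 nM, and a limit rather than a number is quite possible.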

Compound 4, half-maximal inhibitory concentration: > 100000 nM
Compound 4: only a limit was reported; the forecaster's own chance of this, stated with the estimate: 60%; the middle value sits exactly at the limit.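

Compound 4 is reported in this assay only as a limit, > 100000 nM. The new step is a number no lower from compound 1 to compound 4 (the limit leaves the size open), and neither it nor any other step among these compounds can be read, because each one ends on or starts from the same limit: the limit of > 100000 nM in this assay, at which 3 of the 4 values shown sit. This shows that the change from 4-chlorophenyl to 4-methoxyphenyl gives no readable number on either core, but it does not show that the change has no effect or that its size carries over from one core to the other.

From the compounds shown here alone, what stays open is whether another group in place of the chloro, such as an amine or a carboxylic acid, would give a readable number in this assay on the core of compound 1. Any such number would be needed before a change in this series could be sized or compared between cores.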